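The compounds below may be only part of what the source reports. "The series", "measured", "known", "first", "only" and "open" are said of these compounds alone.

Measured so far in an ADME assay on Vero C1008 cells (Chlorocebus sabaeus) for cytotoxicity, read by MTT assay, with a stated time of 72 h; a higher number here means that more compound is tolerated, a lower number that less compound is tolerated:
- compound 1 `Cc1scnc1COc1cc(Cl)cc(-c2cc(-c3c[nH]c(=O)[nH]c3=O)cn(-c3cccnc3)c2=O)c1`: > 100000 nM, a limit of the assay rather than a number
- compound 2 `O=c1[nH]cc(-c2cc(-c3cc(Cl)cc(OCc4ocnc4C(F)(F)F)c3)c(=O)n(-c3cccnc3)c2)c(=O)[nH]1`: > 100000 nM, likewise a limit
- compound 3 `Cn1cc(-c2cc(-c3cc(Cl)cc(OCC4CC4)c3)c(=O)n(-c3cccnc3)c2)c(=O)[nH]c1=O`: 82000 nM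

Going by the values given here, compound 3 gives the only read number in this assay; the other two values are limits (the limit of > 100000 nM in this assay, at which 2 of the 3 values shown sit). Compound 4 `Cn1cc(-c2cc(-c3cc(Cl)cc(OCc4scnc4C(F)(F)F)c3)c(=O)n(-c3cccnc3)c2)c(=O)[nH]c1=O` differs from compound 3 by a group of 9 heavy atoms (4 carbon, 1 nitrogen, 3 fluorine, 1 sulfur; one five-membered aromatic ring with 2 hetero atoms) in place of a group of 3 heavy atoms (3 carbon; one three-membered non-aromatic ring of carbon only), on a saturated chain carbon bound to an oxygen on an aromatic ring. Among the compounds with values here, the only measured step at that position, a step that the two limits leave unreadable from compound 1 to compound 2, runs between two limits and therefore tells nothing about size or direction. Within the data shown here, no measured step fixes the expectation, and compound 3 already lies near the limit region of this assay. Compound 4 is expected to tolerate about 100000 nM, with a range from 45000 nM to 220000 nM. The expected step is a 1.2-fold higher number from compound 3 to compound 4 (0.09 log units; within the scatter), most likely ending at a limit again.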

Compound 4, half-maximal cytotoxic concentration: > 100000 nM
Compound 4: only a limit was reported; the forecaster's own chance of this, stated with the estimate: 55%; the middle value sits exactly at the limit.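

In this assay compound 4 gives > 100000 nM, a limit and not a number. With the trifluoromethyl-bearing five-membered aromatic ring in place of cyclopropyl on the saturated chain carbon, the position yields its first step with a readable floor, an at least 1.2-fold higher number from compound 3 to compound 4 (0.08 log units; that floor lies within the scatter), whereas the earlier step between two limits cannot be read. Most of the series now sits at the ceiling: the limit of > 100000 nM in this assay, at which 3 of the 4 values shown sit.

As far as these compounds go, the actual values of compound 1, compound 2 and compound 4 stay open. Also open, from the compounds shown here alone, is what an amine or a carboxylic acid would give in this place.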